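The source may hold more compounds than are shown below. What is called first, only, known or untested is meant among the compounds shown, and "the series" means these compounds.

Measured compounds:
- compound 1, `O=C(Oc1ccc(-c2cncn2C2CCN(C(=O)c3ccc(Cl)c(C(F)(F)F)c3)CC2)cc1)c1ccccc1`: > 10000 nM
- compound 2, `COc1ccc(C(=O)N2CCC(n3cncc3-c3ccc(OS(=O)(=O)c4cccc5cnccc45)cc3)CC2)cc1`: 77 nM
- compound 3, `O=C(c1ccc(Cl)c(C(F)(F)F)c1)N1CCC(c2nc3cc(OS(=O)(=O)c4cccc5cnccc45)ccc3[nH]2)CC1`: 31 nM

In an assay on HEK293 cells for antagonist activity at P2X purinoceptor 7 (Homo sapiens), read by fluorescence, with a stated time of 2 h (a lower number here means a stronger inhibitor, a higher number a weaker inhibitor), compound 1 reaches only the limit of the assay, (the limit of > 10000 nM in this assay, at which 1 of the 3 values shown sits), and not a number. Compound 2 gives 77 nM in this assay. Compound 3 gives 31 nM in this assay and stands lowest of the two numbers shown; compound 2 sits beyond the usual scatter from it. Compound 1 contributes only a limit, not a number. Within the data shown here, compound 2 carries a different core from compound 3, so no step between measured compounds isolates a single change.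

Compound 4, `O=C(c1ccc([N+](=O)[O-])cc1)N1CCC(c2nc3cc(OS(=O)(=O)c4cccc5cnccc45)ccc3[nH]2)CC1`, has not yet been measured in this assay. It differs from compound 3 in one place: 4-nitrophenyl in place of 4-chloro-3-(trifluoromethyl)phenyl on a carbonyl carbon. The piperidine, the benzimidazole-type core and the sulfonate-linked isoquinoline part are kept. Among the measured compounds shown here, no measured pair shows what this exchange on the carbonyl carbon does, so any expectation rests on the standing of compound 3 alone. A modest weakening is expected, with the step from compound 3 to compound 4 estimated as a 1.9-fold higher number from compound 3 to compound 4 (0.29 log units; within the scatter). Compound 4 is therefore expected to give about 60 nM in this assay, in a range from 20 nM to 200 nM.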

Compound 4, half-maximal inhibitory concentration: 13 nM
Beside the measured number, compound 4's estimate is 4.6-fold (0.66 log units) above it; the whole stated range lies above it.
By their numbers in this assay, from the lowest: compound 4; then compound 3; then compound 2. At a limit, above all of these: compound 1.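

In this assay, the exchange on the carbonyl carbon gives a 2.4-fold lower number from compound 3 to compound 4 (0.38 log units; beyond the scatter), the first step among these compounds that isolates a single change. It shows that 4-chloro-3-(trifluoromethyl)phenyl is not needed at this position on the carbonyl carbon: 4-nitrophenyl, which carries hydrogen-bond acceptors where the group it replaces carries none, gives the lower number on the same core. Nothing among the data shown bears on the cause of this step.

Going by these compounds, with one exchange at this position, it remains open whether a nitrile, a carboxylic acid or an amine in place of the nitro group on the phenyl ring would keep or lose this gain. On these data alone, it also remains open whether the same exchange would give a similar step on the core of compound 2.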